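Ring size at the aryl ether: compound 2 to compound 3

The source may report more compounds than this note shows. Statements on the series, on what has been measured and on what is new or still open speak of the compounds shown alone.

Measured so far:
- compound 1, `CCc1cn(CCCc2ccc(OC3CCNCC3)cc2)c(-c2cc3sccc3n2C)n1`, 61.4%
- compound 2, `Cn1c(-c2nc(C3CCC3)cn2CCCc2ccc(OC3CCCNCC3)cc2)cc2sccc21`, 74.2%

In a functional assay on THP-1 cells (Homo sapiens) for inhibition, read by colony formation, with a stated time of 13 days, tested at 500 nM (a higher number here means a stronger effect of the compound at the concentration tested, a lower number a weaker effect), compound 2 holds the higher of the two numbers; compound 1 sits lower by a gap beyond the scatter. Within the data shown here, no pair of these two compounds differs in only one place, so the gap between them shows only what the two values are, not what any single change does.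

Compound 3, `Cn1c(-c2nc(C3CCC3)cn2CCCc2ccc(OC3CCNCC3)cc2)cc2sccc21`, is the next member and differs from compound 2 in one place: piperidin-4-yl in place of azepan-4-yl on an oxygen on an aromatic ring. The same piperidin-4-yl group appears in compound 1, but compound 1 also carries a different group on the shared core, so it is not a clean guide.

Among the measured compounds shown here, no step between measured compounds is known. The change from a seven-membered to a six-membered non-aromatic ring at this oxygen is expected to give a modest step downward, possibly within the scatter, in this assay, estimated as a number 8.2 percentage points lower from compound 2 to compound 3 (within the scatter). Compound 3 is therefore expected to give 66% in this assay, in a range from 52% to 80%.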

Compound 3, a percentage reported as inhibition, at one concentration (the size of the read-out at that concentration, not a potency): 72.3%
Estimate against measurement, compound 3: 6.3 percentage points below, within the range that was stated.
By their numbers in this assay, from the lowest: compound 1; then compounds 3 and 2 (each within the scatter of the next).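

In this assay, the ether ring tolerates the change from azepan-4-yl to piperidin-4-yl on an oxygen on an aromatic ring, with the two values within the scatter of each other (a number 1.9 percentage points lower from compound 2 to compound 3 (within the scatter)). This gives the series its first single-place reading at this position. Compound 1 could not give that reading, as a comparison with compound 2 would also involve a different group on the shared core. Compound 3 also isolates that other difference, and cyclobutyl in place of ethyl on an aromatic carbon gives a modest step beyond the scatter (a number 10.9 percentage points higher from compound 1 to compound 3 (beyond the scatter)), so of the two places, only this one has shown a step of that kind. Nothing available bears on the reason for either step.

Whether the tolerance at the oxygen extends beyond these two rings remains open, for example to pyrrolidin-3-yl or to an open chain ending in an amine, and a methyl group on the ring nitrogen is equally untested in the compounds shown. The cyclobutyl step is also known only with piperidin-4-yl in place, so a cyclopropyl or a tert-butyl group on that aromatic carbon would show how far it extends.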